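Fluorine additions in a pyrazole amide series

This account rests on a few compounds, and the source may have more. Where it says the series, first, only, none or still open, it means among the compounds named here.

Compound 1 `O=C(Nc1nc2ccccc2s1)c1cn(-c2ccccc2)nc1-c1ccccc1` is the parent of the set; in a functional assay on HT-29 cells (Homo sapiens) for cytotoxicity, read by MTT assay, with a stated time of 72 h (a higher number here means a weaker inhibitor, a lower number a stronger inhibitor), compound 1 gives 16800 nM. Compound 2 `O=C(Nc1nc2ccc(F)cc2s1)c1cn(-c2ccccc2)nc1-c1ccccc1` differs from it by fluoro in place of hydrogen on an aromatic carbon; in this assay compound 2 gives 9800 nM, and the step reads a 1.7-fold lower number from compound 1 to compound 2 (0.23 log units; within the scatter). Compound 3 `O=C(Nc1nc2ccccc2s1)c1cn(-c2ccccc2)nc1-c1ccc(F)cc1` also differs from the parent by fluoro in place of hydrogen on an aromatic carbon, at another place; in this assay compound 3 gives 9060 nM, with a 1.9-fold lower number from compound 1 to compound 3 (0.27 log units; within the scatter). Compound 3 thus has the lowest number of the three, but its gaps to compound 2 and to compound 1 are both within the scatter, so no order among them can be claimed.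

Compound 4 `O=C(Nc1nc2ccc(F)cc2s1)c1cn(-c2ccccc2)nc1-c1ccc(F)cc1` carries both fluoro substituents. Relative to compound 3 the change is fluoro in place of hydrogen on an aromatic carbon. The same change has been made once before in this set, where it gave a 1.7-fold lower number from compound 1 to compound 2 (0.23 log units; within the scatter), within the scatter. Whether the two changes add up is not shown by anything here. A step of similar size is expected in this assay, downward if at all and within the scatter, namely a 1.6-fold lower number from compound 3 to compound 4 (0.21 log units; within the scatter). Compound 4 is therefore estimated at 5600 nM, with a range from 2500 nM to 12500 nM.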

Compound 4, half-maximal inhibitory concentration: 4160 nM
The estimate for compound 4 lay 1.3-fold (0.13 log units) above the measured number; measured number inside the range.
By their numbers in this assay, from the lowest: compound 4; then compounds 3, 2 and 1 (each within the scatter of the next).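

With both fluoro groups present, each single addition now clears the scatter in this assay: the change from 1,3-benzothiazol-2-yl to 6-fluoro-1,3-benzothiazol-2-yl gives a 2.2-fold lower number from compound 3 to compound 4 (0.34 log units; beyond the scatter), and the other fluoro addition gives a 2.4-fold lower number from compound 2 to compound 4 (0.37 log units; beyond the scatter). The first change has now been read on two cores, and its size holds whether or not the other fluoro is present: the same change on two cores in this assay, a 1.7-fold lower number (0.23 log units; within the scatter) from compound 1 to compound 2 and a 2.2-fold lower number (0.34 log units; beyond the scatter) from compound 3 to compound 4, 1.3-fold (0.10 log units) apart, within the scatter of two such steps. The other addition reads the same way, so the two fluoro additions behave as roughly independent steps across these four compounds, with none going against this: the same change on two cores in this assay, a 1.9-fold lower number (0.27 log units; within the scatter) from compound 1 to compound 3 and a 2.4-fold lower number (0.37 log units; beyond the scatter) from compound 2 to compound 4, 1.3-fold (0.10 log units) apart, within the scatter of two such steps.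

The compounds shown leave open whether chloro, methoxy or an amine in place of the fluoro at the position para to a fused ring would move the number in the same direction, or whether the step is particular to fluoro. They also leave open whether any other pair of groups on the shared core would combine in the same way.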